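Amine exchange in the series: compound 3 to compound 4

The compounds below may be only part of what the source reports. "The series", "measured", "known", "first", "only" and "open" are said of these compounds alone.

In a functional assay on LNCaP cells (Homo sapiens) for antiproliferative activity, read by WST assay, with a stated time of 3 days (on this read-out higher numbers stand for weaker inhibition and lower numbers for stronger inhibition), compound 1 (`CCN(CC)CCCCOc1c(-c2cc(OC)c(OC)c(OC)c2)oc2ccccc2c1=O`) gives 13500 nM, compound 2 (`CCCN(CCC)CCCCOc1c(-c2cc(OC)c(OC)c(OC)c2)oc2ccccc2c1=O`) gives 16800 nM and compound 3 (`CCCCN(CCCC)CCCCOc1c(-c2cc(OC)c(OC)c(OC)c2)oc2ccccc2c1=O`) gives 7800 nM. Compound 3 separates from only one of the other two: the data show a 2.2-fold lower number from compound 2 to compound 3 (0.33 log units; beyond the scatter), against a 1.7-fold lower number from compound 1 to compound 3 (0.24 log units; within the scatter).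

The next compound is compound 4 (`CCCCCN(CCCCC)CCCCCOc1c(-c2cc(OC)c(OC)c(OC)c2)oc2ccccc2c1=O`), with the change ((dipentylamino)methyl in place of dibutylamino on a saturated chain carbon, four bonds along the chain from an oxygen on an aromatic ring). The three measured steps bear on this change, as all of them exchange the amino group at this place. Besides the two above, the data show a 1.2-fold higher number from compound 1 to compound 2 (0.09 log units; within the scatter). These steps do not run in one direction, and the largest is modest. None of them covers the extra methyl unit in (dipentylamino)methyl, so the new step goes beyond what has been measured.

In this assay, among the measured compounds shown here, no step clearly beyond the scatter is expected, with a slight lean toward a lower number resting on a 2.2-fold lower number from compound 2 to compound 3 (0.33 log units; beyond the scatter). The estimated step is a 1.4-fold lower number from compound 3 to compound 4 (0.15 log units; within the scatter). For compound 4 the expected value is 5500 nM, with an estimated range of 2200 nM to 14000 nM.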

Compound 4, half-maximal inhibitory concentration: 7900 nM
Compound 4: the middle estimate sits 1.4-fold (0.16 log units) below what was measured; the range from low to high includes it.
By their numbers in this assay, from the lowest: compounds 3, 4, 1 and 2 (each within the scatter of the next, the first and the last beyond it).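

In this assay, the exchange of dibutylamino for (dipentylamino)methyl, with 12 heavy atoms entering against 9 leaving, gives no separation from compound 3 (a 1.0-fold higher number from compound 3 to compound 4 (0.01 log units; within the scatter)), so this place on the saturated chain accepts the larger group without a step beyond the scatter. Compound 4 also takes the same standing as compound 3 towards the two smaller amines: it separates from the dipropylamino compound (a 2.1-fold lower number from compound 2 to compound 4 (0.33 log units; beyond the scatter)) but not from the diethylamino compound (a 1.7-fold lower number from compound 1 to compound 4 (0.23 log units; within the scatter)), so across the four compounds the only separations are those of compound 3 and compound 4 from compound 2. No measurement on the compounds shown offers an explanation for these numbers.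

The exchange joins two changes, the pentyl groups on the nitrogen and the extra methyl unit, and a dipentylamino group on the chain of compound 3 would be needed to tell their contributions apart. As far as these compounds go, it also remains open whether a ring amine such as piperidine or morpholine at this place would stay level with the open-chain amines.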